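A few compounds are considered here, and "the series" means these few. Any claim that something is new, unique, unknown or untested is made for them only; others in the source may bear on it.

In an ADME assay on RAW264.7 cells (Mus musculus) for cytotoxicity, read by MTT assay, with a stated time of 24 h, in the absence of a further agent (a lower number here means a stronger inhibitor, a higher number a weaker inhibitor), three compounds have been tested so far, and none has given a figure beyond a limit. Compound 1 (`Cc1noc(CC2OC(=O)c3ccccc32)n1`) reads > 40000 nM, which is a limit of the assay. Compound 2 (`O=C1OC(Cc2nc(-c3ccc(-c4ccccc4)cc3)no2)c2ccccc21`) reads > 40000 nM, again a limit. Compound 3 (`CCOc1ccc(C(O)C2OC(=O)c3c(OC)cc(OC)cc32)cc1`) reads > 40000 nM, also a limit. The set therefore stands together at the limit of > 40000 nM in this assay, at which 3 of the 3 values shown sit, and compound 3 cannot be ranked against the other two.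

Compound 4 (`COCCCCOc1ccc(C(O)C2OC(=O)c3c(OC)cc(OC)cc32)cc1`) differs from compound 3 by one change, 2-methoxyethyl in place of hydrogen on a saturated chain carbon, two bonds along the chain from an oxygen on an aromatic ring. Put another way, ethoxy becomes 4-methoxybutoxy. For the measured compounds named here, no measured pair in the set shows what a change of this kind does in this assay, so no step beyond the scatter is expected, in either direction. The expected step is a number no higher from compound 3 to compound 4 (the limit leaves the size open). Compound 4 is estimated at 40000 nM, with an expected range from 20000 nM to 80000 nM, and the reading will most likely be a limit again.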

Compound 4, half-maximal inhibitory concentration: > 40000 nM
Compound 4: only a limit was reported (the forecaster's own chance of this, stated with the estimate: 85%); the middle value sits exactly at the limit.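

In this assay compound 4 gives > 40000 nM, which is a limit, and compound 3 stands at a limit too, so no step can be read between compound 3 and compound 4. The compounds shown leave open whether any structural change moves a reading off this shared limit: the limit of > 40000 nM in this assay, at which 4 of the 4 values shown sit.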